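The source may report more compounds than this note shows. Statements on the series, on what has been measured and on what is new or still open speak of the compounds shown alone.

Measured so far in a functional assay on A549 cells (Homo sapiens) for cytotoxicity, read by MTT assay, with a stated time of 6 days; on this read-out higher numbers stand for an effect only at larger amounts of compound and lower numbers for an effect already at smaller amounts:
- compound 1 `COC(=O)c1c(-c2cc(OC)cc(OC)c2)oc2ccccc2c1=O`: > 25 ug/mL (a limit)
- compound 2 `COC(=O)c1c(-c2ccc(OC)cc2)oc2ccccc2c1=O`: > 25 ug/mL (a limit)

Within the data shown here, neither reading is a number, and the series so far is described by one entry: the limit of > 25 ug/mL in this assay, at which 2 of the 2 values shown sit. Compound 2 therefore has a limit as its only standing in this assay, and no rank against compound 1 can be drawn from the two readings.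

Compound 3 `COC(=O)c1c(-c2ccc(Br)cc2)oc2ccccc2c1=O` has not yet been measured. It differs from compound 2 as follows: bromo in place of methoxy on an aromatic carbon. In words, this is bromo in place of methoxy on an aromatic carbon, para to a large group.

Among the measured compounds shown here, no step between measured compounds is available to size this change, so no shift beyond the scatter is expected in this assay, and no direction is favoured. The expectation rests on compound 2, whose reading of > 25 ug/mL remains a limit. The expected step is a step that the limit leaves unreadable from compound 2 to compound 3 and is an estimate only. A reported limit is also expected to be more likely than a number. Compound 3 is estimated at 30 ug/mL, with an expected range from 12 ug/mL to 60 ug/mL.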

Compound 3, concentration for half-maximal effect: > 25 ug/mL
Compound 3: a limit, no number; the forecaster's own chance of this, stated with the estimate: 65%; the middle value is on the limit's open side.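

Compound 3 reads as a limit in this assay, as compound 2 does, so bromo in place of methoxy gives no readable step between compound 2 and compound 3. The series still rests on a single entry: the limit of > 25 ug/mL in this assay, at which 3 of the 3 values shown sit.

The compounds shown leave open whether any member of the series gives a number in this assay, and how the groups would rank there.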